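The compounds below may be only part of what the source reports. "The series", "measured", "known", "first", "only" and "open" are said of these compounds alone.

Compound 3, with the structure `CC(C)(C)c1nc(NC#N)ncc1-c1ccccc1`, is one of three analogues measured in a functional assay on the whole organism for inhibition, with Rattus norvegicus as the target, with stated times of 1 h and 3.5 h, at a dose of 100 mg/kg by the oral route; on this read-out lower numbers stand for less inhibition and higher numbers for more inhibition at the one dose given (going by the name of the read-out). In this assay compound 3 reports only a limit, < 5%. Compound 2, `CC(C)(C)c1nc(-c2ccccc2)ncc1-c1ccccc1`, likewise reports only a limit in this assay, < 5%. Within the data shown here, the one full number belongs to compound 1, `CC(C)(C)c1nc(N)ncc1-c1ccccc1`, which in this assay gives 46%. Two of the three results therefore sit together at the floor of the read-out (the limit of < 5% in this assay, at which 2 of the 3 values shown sit), and compound 3 stands there.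

The next compound, compound 4, has the structure `CCOC(=O)Nc1ncc(-c2ccccc2)c(C(C)(C)C)n1`. ethoxycarbonyl in place of cyano on a nitrogen on an aromatic ring

Among the measured compounds shown here, two measured steps bear on this change. The step of a number at least 41 percentage points lower from compound 1 to compound 3 (beyond the scatter) shows that placing a group on that nitrogen removed nearly all of the inhibition seen for compound 1. The step of a number at least 41 percentage points lower from compound 1 to compound 2 (beyond the scatter) shows a loss of similar size for a different change at the same carbon. The step that the two limits leave unreadable from compound 2 to compound 3 cannot be read, since both ends are limits. Compound 4 again carries a group on that nitrogen, so the expectation is that it stays low rather than returning toward compound 1, with the step of a number at least 7 percentage points higher from compound 3 to compound 4 (that floor lies within the scatter) expected to be small or not beyond the scatter. Compound 4 is estimated at 12%, between 0% and 40%.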

Compound 4, a percentage reported as inhibition, in the whole organism at one dose (the size of the read-out at that dose, not a potency): 24%
The estimate for compound 4 lay 12 percentage points below the measured number; measured number inside the range.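

In this assay, the change from cyano to ethoxycarbonyl on this nitrogen gives a number at least 19 percentage points higher from compound 3 to compound 4 (beyond the scatter), so a group on the nitrogen does not in itself bring the read-out down to the floor. Among these compounds, the free amino compound still keeps the advantage, with a number 22 percentage points lower from compound 1 to compound 4 (beyond the scatter), which places the ethoxycarbonyl compound at an intermediate level that none of the earlier compounds occupied. At the aromatic carbon, (ethoxycarbonyl)amino in place of phenyl gives a number at least 19 percentage points higher from compound 2 to compound 4 (beyond the scatter); this step and the one from the cyano compound are minimum sizes, and the step between compound 2 and compound 3 cannot be read, as these compounds rest on limits: the limit of < 5% in this assay, at which 2 of the 4 values shown sit.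

With only hydrogen, cyano and ethoxycarbonyl shown on this nitrogen, the compounds leave open which feature of the ethoxycarbonyl group goes with the recovered inhibition, and whether the carbonyl or the ethyl chain matters. An acetyl group, a methyl group or a longer butoxycarbonyl chain on the same nitrogen would bear on that question, and so would a simple methylamino or dimethylamino group at the aromatic carbon.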